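The compounds below may be only part of what the source reports. "The series", "measured", "known", "first", "only" and "open" are said of these compounds alone.

In a functional assay on HeLa cells (Homo sapiens) for cytotoxicity, read by WST assay, with a stated time of 48 h (a higher number here means a weaker inhibitor, a lower number a stronger inhibitor), compound 1 `O[C@@H](c1ccccc1)[C@H]1CO[C@H](c2ccccc2)[C@@H](C/C=C/C2CCCC2)C1` gives 9330 nM and compound 2 `O=[N+]([O-])c1ccc(/C=C/C[C@H]2C[C@@H]([C@@H](O)c3ccccc3)CO[C@@H]2c2ccccc2)cc1` gives 12400 nM. These two numbers lie within the usual scatter of each other, so compound 2 stands level with compound 1. Compound 3 `O=[N+]([O-])c1ccccc1/C=C/C[C@H]1C[C@@H]([C@@H](O)c2ccccc2)CO[C@@H]1c1ccccc1` keeps the shared core and alters one group: 2-nitrophenyl in place of 4-nitrophenyl on a double-bonded chain carbon bound to a double-bonded chain carbon. Going by the values given here, only one measured step bears on this change. Placing 4-nitrophenyl where cyclopentyl stood, on the same double-bonded chain carbon, gave a 1.3-fold higher number from compound 1 to compound 2 (0.12 log units; within the scatter). Even that exchange of two different groups left the number within the scatter. Among the compounds with values here, no step beyond the scatter is therefore expected in this assay, in either direction, although no measured compound carries 2-nitrophenyl. The estimated change is a 1.1-fold lower number from compound 2 to compound 3 (0.05 log units; within the scatter). Compound 3 is expected to give about 11000 nM, with an estimated range from 5500 nM to 22000 nM.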

Compound 3, half-maximal inhibitory concentration: 11800 nM
Estimate against measurement, compound 3: 1.1-fold (0.03 log units) below; the range from low to high includes it.
By their numbers in this assay, from the lowest: compounds 1, 3 and 2 (each within the scatter of the next).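

Exchanging 4-nitrophenyl for 2-nitrophenyl on a double-bonded chain carbon bound to a double-bonded chain carbon gives a 1.1-fold lower number from compound 2 to compound 3 (0.02 log units; within the scatter) in this assay and so leaves the number level, which shows that this change of the nitro group's place on the ring does not separate the two compounds here. Set against cyclopentyl, the new group gives a 1.3-fold higher number from compound 1 to compound 3 (0.10 log units; within the scatter) and so also stands level, which means that all three groups at this place now read alike in this assay. No separate data bear on why these numbers stay level.

Going by these compounds, whether an amine, a carboxylic acid or a longer chain at this place would give a step beyond the scatter remains open. Only this one place varies among the compounds shown, so the role of the rest of the shared core also remains open.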